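Chain shortening at the amino substituent: compound 3 to compound 4

This account rests on a few compounds, and the source may have more. Where it says the series, first, only, none or still open, it means among the compounds named here.

Measured compounds, with the dose found in a functional assay on the whole organism for activation, with Mus musculus as the target; a lower number here means that less compound is needed, a higher number that more compound is needed for the effect:
compound 1, `CCCSc1nc(N)c2nc(O)n(Cc3ccccc3)c2n1`, gives 0.1 mg/kg
compound 2, `CCCCc1nc(N)c2nc(O)n(Cc3ccccc3)c2n1`, gives 0.3 mg/kg
compound 3, `CCCCCNc1nc(N)c2nc(O)n(Cc3ccccc3)c2n1`, gives 0.3 mg/kg

Compound 3 stands level with compound 2 to the digits reported, and the two together hold the highest number of the three. Its nearest neighbour is compound 2, with no change at the digits printed from compound 2 to compound 3 (within the scatter); its furthest is compound 1, with a 3.0-fold higher number from compound 1 to compound 3 (0.48 log units; beyond the scatter).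

Compound 4, `CCCCNc1nc(N)c2nc(O)n(Cc3ccccc3)c2n1`, differs from compound 3 by hydrogen in place of methyl on a saturated chain carbon, four bonds along the chain from a nitrogen on an aromatic ring. Within the data shown here, no measured step shortens a chain by one carbon, so the bearing of the known steps is indirect. no change at the digits printed from compound 2 to compound 3 (within the scatter) shows that exchanging the whole butyl for pentylamino on the aromatic carbon left the number unchanged, and a 3.0-fold higher number from compound 1 to compound 2 (0.48 log units; beyond the scatter) together with a 3.0-fold higher number from compound 1 to compound 3 (0.48 log units; beyond the scatter) show only modest shifts even when the group on that carbon is replaced entirely. Removing a single terminal carbon from the pentylamino chain is a smaller change than any of these. Compound 4 is therefore expected to give 0.3 mg/kg, in the range 0.1 mg/kg to 1 mg/kg, which means an expected step of no change at the digits printed from compound 3 to compound 4 (within the scatter) that stays within the scatter.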

Compound 4, minimum effective dose: 0.1 mg/kg
Compound 4: middle estimate off by 3.0-fold (0.48 log units), on the high side; measured number inside the range.
By their numbers in this assay, from the lowest: compounds 1 and 4 (each within the scatter of the next); then compounds 2 and 3 (each within the scatter of the next).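

In this assay, the end of the pentylamino chain proves not to be silent: hydrogen in place of methyl, four bonds along the chain from a nitrogen on an aromatic ring, gives a 3.0-fold lower number from compound 3 to compound 4 (0.48 log units; beyond the scatter) and so moves the number by a single carbon as far as the exchanges of the whole group did. The amino nitrogen alone does not set the number: butylamino in place of butyl gives a 3.0-fold lower number from compound 2 to compound 4 (0.48 log units; beyond the scatter) whereas pentylamino in place of butyl gave no change at the digits printed from compound 2 to compound 3 (within the scatter) and butylamino in place of propylsulfanyl gives no change at the digits printed from compound 1 to compound 4 (within the scatter) so the length of the chain on the nitrogen separates two compounds that otherwise match. Nothing at hand accounts for this one-carbon shift, and its origin stays unknown.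

The compounds shown leave open whether the number continues along the chain or turns, which a propylamino, an ethylamino or a longer hexylamino group would settle. Also open, from the compounds shown here alone, is whether the same one-carbon difference counts on the sulfur-linked side, where a butylsulfanyl or ethylsulfanyl group would be the direct comparison.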